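The compounds below may be only part of what the source reports. "The series", "measured", "known", "first", "only" and "open" are said of these compounds alone.

Measured in a functional assay on MCF7 cells (Homo sapiens) for inhibition; on this read-out higher numbers stand for weaker inhibition of growth and lower numbers for stronger inhibition of growth:
- Compound 1 `COc1ccc(-n2cnnc2-c2cc(OC)c(OC)c(OC)c2)cc1`: 1700 nM
- Compound 2 `COc1cc(-c2nncn2-c2ccc(N(C)C)cc2)cc(OC)c1OC`: 275 nM

Compound 1, at 1700 nM, holds the higher of the two numbers in this assay. Compound 3 `COc1ccc(-n2cnnc2-c2cc(OC)c(OC)c(OC)c2)cc1O` carries one change from compound 1: hydroxy in place of hydrogen on an aromatic carbon. Among the compounds with values here, no measured step adds a hydroxy group. The nearest guide is the modest change from compound 1 to compound 2, another change on an aromatic carbon, with a 6.2-fold lower number from compound 1 to compound 2 (0.79 log units; beyond the scatter). A move towards stronger inhibition of growth is therefore expected, and the estimated step is a 10-fold lower number from compound 1 to compound 3 (1.00 log units; beyond the scatter). Compound 3 is expected at 170 nM, within an estimated range of 25 nM to 1000 nM.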

Compound 3, concentration for 50% growth inhibition: 617 nM
Estimate against measurement, compound 3: 3.6-fold (0.56 log units) below; measured number inside the range.
By their numbers in this assay, from the lowest: compound 2; then compound 3; then compound 1.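

In this assay, hydroxy in place of hydrogen on an aromatic carbon, ortho to a methoxy group, gives a 2.8-fold lower number from compound 1 to compound 3 (0.44 log units; beyond the scatter), a step beyond the scatter. Within the data shown here, this shows that a position left carrying hydrogen in the earlier compounds can take a new group with stronger inhibition of growth. No evidence given here accounts for this step.

On these data alone, whether an amino group or a fluorine atom at this position would move the number in the same direction remains open. So does the effect of this hydroxy group when dimethylamino replaces the methoxy group of compound 1.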